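The source may report more compounds than this note shows. Statements on the series, on what has been measured and on what is new or still open speak of the compounds shown alone.

Working notes on the series, read in a functional assay on HL-60 cells (Homo sapiens) for inhibition, read by CCK-8 assay, with a stated time of 48 h, tested at 20 uM (a lower number here means less inhibition of growth, a higher number more inhibition of growth at the concentration tested), throughout. Compound 1 (`Cc1ccc(S(=O)(=O)Oc2ccccc2/C=C(\C#N)C(=O)Nc2nnc(C)s2)cc1`) gives 78% in this read-out, and compound 2 (`COc1ccc(S(=O)(=O)Oc2ccccc2/C=C(\C#N)C(=O)Nc2nnc(-c3cccs3)s2)cc1`) gives 67% on the same scale. Compound 3 (`Cc1nnc(NC(=O)/C(C#N)=C/c2cccc(OS(C)(=O)=O)c2)s1`) gives 20% as the lowest of the three numbers, and its gaps to compound 2 and to compound 1 both lie beyond the usual scatter. No two of these compounds differ in one place only, so no single structural change can be read directly from them.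

Compound 4 (`Cc1ccc(S(=O)(=O)Oc2cccc(/C=C(\C#N)C(=O)Nc3nnc(C)s3)c2)cc1`) departs from compound 3 in one place: 4-methylphenyl in place of methyl on a sulfonyl sulfur. The closest indirect evidence is that compound 1 also carries 4-methylphenyl on a sulfonyl sulfur and gives 78% in this assay. Compound 1 differs from compound 4 elsewhere as well, so this comparison supports a direction more firmly than a size. Among the compounds with values here, the expected step is upward and beyond the scatter, an estimated a number 38 percentage points higher from compound 3 to compound 4 (beyond the scatter) (with a wide margin, as no direct step is available). For compound 4 the expected value is 58%, with an estimated range from 32% to 82%.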

Compound 4, percent growth inhibition at one concentration: 71%
Compound 4: the middle estimate sits 13 percentage points below what was measured; the measured number falls inside the stated range.
By their numbers in this assay, from the lowest: compound 3; then compounds 2, 4 and 1 (each within the scatter of the next, the first and the last beyond it).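

In this assay the replacement of methyl by 4-methylphenyl on the sulfonyl sulfur, whose other neighbour is oxygen on an aromatic ring, gives a number 51 percentage points higher from compound 3 to compound 4 (beyond the scatter) at the concentration tested. Within the data shown here, this is the first change that can be read in isolation, and it shows that growth inhibition in this read-out responds strongly to the group at this sulfonyl sulfur, with the rest of the structure held constant. The measurements shown give no information on the origin of this step.

One pair cannot show whether the gain belongs to the 4-methylphenyl group specifically or would also appear with another group on the sulfonyl sulfur, such as a longer chain like butyl, an unsubstituted phenyl, or a phenyl ring carrying an amine or a carboxylic acid. Also open is whether the same replacement would give a step of similar size in the core of compound 1 or of compound 2, where no partner differing only at the sulfonyl sulfur is shown.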